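The compounds below may be only part of what the source reports. "The series", "measured", "known", "first", "only" and "open" are said of these compounds alone.

In a functional assay on HepG2 cells (Homo sapiens) for cytotoxicity, read by MTT assay, with a stated time of 24 h (a higher number here means a weaker inhibitor, a lower number a stronger inhibitor), compound 3 `O=C1/C(=C/c2cccnc2)CN(S(=O)(=O)c2ccc([N+](=O)[O-])cc2)C/C1=C\c1ccccc1C(F)(F)F` gives 9370 nM and sits level with compound 2 `O=C1/C(=C/c2cccnc2)CN(S(=O)(=O)c2ccccc2)C/C1=C\c1ccccc1C(F)(F)F` at 5370 nM within the scatter, while compound 1 `CN1C/C(=C\c2cccnc2)C(=O)/C(=C/c2ccccc2C(F)(F)F)C1` at 2550 nM has the lowest number of the three. Compound 4 `N#Cc1ccc(S(=O)(=O)N2C/C(=C\c3cccnc3)C(=O)/C(=C/c3ccccc3C(F)(F)F)C2)cc1` differs from compound 3 at one place only: cyano in place of nitro on an aromatic carbon. The measured step that bears on this place is a 1.7-fold higher number from compound 2 to compound 3 (0.24 log units; within the scatter) for nitro in place of hydrogen, and it stays within the scatter. The steps of a 2.1-fold higher number from compound 1 to compound 2 (0.32 log units; beyond the scatter) and a 3.7-fold higher number from compound 1 to compound 3 (0.57 log units; beyond the scatter) came from replacing methyl on an amine nitrogen in a ring, which is a different place. No step beyond the scatter is therefore expected in this assay for this swap. The expected change is a 1.2-fold lower number from compound 3 to compound 4 (0.10 log units; within the scatter) and remains small. In this assay compound 4 is estimated at 7500 nM with 3500 nM to 15000 nM as its likely range.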

Compound 4, half-maximal inhibitory concentration: 5060 nM
Compound 4: middle estimate off by 1.5-fold (0.17 log units), on the high side; the measured number falls inside the stated range.
By their numbers in this assay, from the lowest: compounds 1, 4, 2 and 3 (each within the scatter of the next, the first and the last beyond it).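

In this assay, cyano in place of nitro gives (a 1.9-fold lower number from compound 3 to compound 4 (0.27 log units; within the scatter)) and cyano in place of hydrogen gives (a 1.1-fold lower number from compound 2 to compound 4 (0.03 log units; within the scatter)), so hydrogen, nitro and cyano on this aromatic carbon all read alike so far. The (4-cyanophenyl)sulfonyl group in place of methyl gives (a 2.0-fold higher number from compound 1 to compound 4 (0.30 log units; within the scatter)), which stays within the scatter, unlike the printed steps to phenylsulfonyl and (4-nitrophenyl)sulfonyl. No measurement here explains these numbers. As far as these compounds go, whether an amine or a carboxylic acid on this carbon would also read level with these groups remains open.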